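A few compounds are considered here, and "the series" means these few. Any claim that something is new, unique, unknown or untested is made for them only; others in the source may bear on it.

Measured so far:

compound 1, `CCCCCCN(Cc1nnn[nH]1)c1ccccc1` — 4.78
compound 2, `Clc1ccccc1CN(Cc1nnn[nH]1)c1ccccc1` — 4.34

Compound 1 was measured in a physicochemical assay for acid dissociation, and gives 4.78, the highest of the two numbers; its nearest neighbour is compound 2, which shows a number 0.44 log units lower from compound 1 to compound 2 (beyond the scatter). That single step is the only one in hand, and it changes the group on the carbon bound to the aromatic nitrogen.

Compound 3, `CCCCCCCCCCCCN(Cc1nnn[nH]1)c1ccccc1`, has not yet been measured. It differs from compound 1 by hexyl in place of hydrogen on a saturated chain carbon, six bonds along the chain from a nitrogen on an aromatic ring. Among the compounds with values here, no measured step touches this position; the one step known, a number 0.44 log units lower from compound 1 to compound 2 (beyond the scatter), concerns a different site, so nothing directly bears on the change.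

Since the alteration lies six bonds along the chain from the aromatic nitrogen and far from the acidic tetrazole, compound 3 is expected to show a number 0.02 log units higher from compound 1 to compound 3 (within the scatter), a step not beyond the scatter, and an estimated value of 4.8 with a range of 4.5 to 5.1.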

Compound 3, acid dissociation constant: 4.92
Beside the measured number, compound 3's estimate is 0.12 log units below it; low and high end bracket the measured number.
By their numbers in this assay, from the lowest: compound 2; then compounds 1 and 3 (each within the scatter of the next).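

In this assay, within the data shown here, hexyl in place of hydrogen on a saturated chain carbon, six bonds along the chain from a nitrogen on an aromatic ring, gives a number 0.14 log units higher from compound 1 to compound 3 (within the scatter), the first reading at this position. A chain extended by hexyl at this place therefore does not separate the two numbers, whereas the step with 2-chlorophenyl in place of pentyl, a number 0.44 log units lower from compound 1 to compound 2 (beyond the scatter), does stand clear of the scatter. Nothing available here accounts for either reading.

The compounds shown leave open whether a longer chain at this position would stay within the scatter of compound 1 as well. They also leave open whether an amine or a carboxylic acid carried on this chain would give a step beyond the scatter, since only plain hydrocarbon chains have been read here.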